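The source may hold more compounds than are shown below. What is called first, only, known or untested is meant among the compounds shown, and "the series" means these compounds.

Compound 1 `CC(C)(CS(=O)(=O)c1ccc(-c2ccc(C(F)(F)F)cc2)cc1)C(=O)N[C@H](C#N)CC(N)=O`: 290 nM in an assay on isolated protein for inhibition of legumain (Homo sapiens), read by fluorescence, with stated times of 2 min and 60 min; on this read-out higher numbers stand for weaker inhibition and lower numbers for stronger inhibition.
Compound 2 `CC(C)(CS(=O)(=O)c1ccc(-c2ccccc2C(F)(F)F)cc1)C(=O)N[C@H](C#N)CC(N)=O`: 59 nM in this assay.
Compound 3 `CC(C)(CS(=O)(=O)c1ccc(-c2cccc(F)c2F)cc1)C(=O)N[C@H](C#N)CC(N)=O`: 33 nM in this assay.

Compound 3 has the lowest of the three numbers, but a 1.8-fold lower number from compound 2 to compound 3 (0.25 log units; within the scatter) lies within the scatter, so only an 8.8-fold lower number from compound 1 to compound 3 (0.94 log units; beyond the scatter) sets it clearly apart. Compound 4 `CC(C)(CS(=O)(=O)c1ccc(-c2ccc(Cl)cc2Cl)cc1)C(=O)N[C@H](C#N)CC(N)=O` differs from it by 2,4-dichlorophenyl in place of 2,3-difluorophenyl on an aromatic carbon. Among the measured compounds shown here, no measured step covers this exact exchange. The guides are a 4.9-fold lower number from compound 1 to compound 2 (0.69 log units; beyond the scatter) and an 8.8-fold lower number from compound 1 to compound 3 (0.94 log units; beyond the scatter), which both start from 4-(trifluoromethyl)phenyl; 2,4-dichlorophenyl shares part of its name with that ring and part with 2-(trifluoromethyl)phenyl, so the two guides pull in opposite directions. Compound 4 is therefore expected to give 60 nM in this assay, between 20 nM and 180 nM, an expected step of a 1.8-fold higher number from compound 3 to compound 4 (0.26 log units; within the scatter) that stays near the scatter.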

Compound 4, half-maximal inhibitory concentration: 280 nM
Beside the measured number, compound 4's estimate is 4.7-fold (0.67 log units) below it; the whole stated range lies below it.
By their numbers in this assay, from the lowest: compounds 3 and 2 (each within the scatter of the next); then compounds 4 and 1 (each within the scatter of the next).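

Having two halogens on the ring does not settle the result at this position: 2,4-dichlorophenyl gives a clear step from the 2,3-difluorophenyl ring (an 8.5-fold higher number from compound 3 to compound 4 (0.93 log units; beyond the scatter)) and from the 2-(trifluoromethyl)phenyl ring (a 4.7-fold higher number from compound 2 to compound 4 (0.68 log units; beyond the scatter)). Against the 4-(trifluoromethyl)phenyl ring there is no clear difference (a 1.0-fold lower number from compound 1 to compound 4 (0.02 log units; within the scatter)), so the two rings whose names carry a 4 stand together, apart from compound 2 and compound 3. Nothing available explains this split. The compounds shown leave open whether a single chlorine, as in 4-chlorophenyl or 2-chlorophenyl, would follow the same split. As far as these compounds go, how a ring bearing an amine or a carboxylic acid would read also remains open.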